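Fluoro in Place of Methyl on an Aromatic Carbon

The compounds below may be only part of what the source reports. "The series", "measured", "known", "first", "only" and "open" are said of these compounds alone.

Three compounds have been measured in an assay on HEK293 cells for inhibition of N-acylethanolamine-hydrolyzing acid amidase (Rattus norvegicus), read by LC-MS, with a stated time of 30 min; on this read-out lower numbers stand for stronger inhibition and higher numbers for weaker inhibition:

compound 1, `Cc1ccccc1CCCCCCC(=O)N1CCCC1`, 68400 nM
compound 2, `Cc1ccc(CCCCCCC(=O)N2CCCC2)cc1`, 9600 nM
compound 3, `O=C(CCCCCCc1ccccc1F)N1CCCC1`, 13700 nM

Compound 1 and compound 2 have the same atoms joined differently; the difference between the two cores is not broken down here. Compound 2 and compound 3 lie within the scatter of each other, while compound 1 stands beyond both. From compound 1 to compound 3 the change is fluoro in place of methyl on an aromatic carbon, and it produced a 5.0-fold lower number from compound 1 to compound 3 (0.70 log units; beyond the scatter).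

Compound 4, `O=C(CCCCCCc1ccc(F)cc1)N1CCCC1`, is not yet measured in this assay. It arises from compound 2 by fluoro in place of methyl on an aromatic carbon: the same kind of change, though here the fluoro sits para to a large group, where in compound 3 it sits ortho to a large group. Because compound 2 already gives 9600 nM, a smaller step than the earlier one is expected, and compound 4 is expected to show a 1.4-fold lower number from compound 2 to compound 4 (0.14 log units; within the scatter). Compound 4 is therefore estimated at 7000 nM, between 2500 nM and 20000 nM.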

Compound 4, half-maximal inhibitory concentration: 8000 nM
Beside the measured number, compound 4's estimate is 1.1-fold (0.06 log units) below it; measured number inside the range.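

In this assay, fluoro in place of methyl on an aromatic carbon gave a 1.2-fold lower number from compound 2 to compound 4 (0.08 log units; within the scatter), so compound 2 and compound 4 cannot be told apart on this read-out. The same change therefore did not carry its size from one core to the other: the same change on two cores in this assay, a 5.0-fold lower number (0.70 log units; beyond the scatter) from compound 1 to compound 3 and a 1.2-fold lower number (0.08 log units; within the scatter) from compound 2 to compound 4, 4.2-fold (0.62 log units) apart, beyond the scatter of two such steps. This shows that the size of the step depends on the core in these two pairs, but it does not show which feature of the cores accounts for the gap, and two pairs set no rule for any further core.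

The compounds shown leave open how chloro or methoxy would compare with methyl and fluoro on either core. They also leave open whether the gap between the two steps would persist with a shorter chain.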